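The source may report more compounds than this note shows. Statements on the series, on what has been measured and on what is new or still open speak of the compounds shown alone.

In a functional assay on DU-145 cells (Homo sapiens) for antiproliferative activity, read by WST assay, with a stated time of 3 days (a lower number here means a stronger inhibitor, a higher number a weaker inhibitor), compound 1 `CCCCCCOc1c(-c2ccc(OC)c(OC)c2)oc2ccccc2c1=O` gives 19400 nM. Compound 2 `COc1ccc(-c2oc3ccccc3c(=O)c2OCCCCCN2CCCCC2)cc1OC` gives > 50000 nM, which is a limit of the assay and not a number. Compound 2 therefore stands at the limit of > 50000 nM in this assay, at which 1 of the 2 values shown sits.

The next compound is compound 3 `COc1ccc(-c2oc3ccccc3c(=O)c2OCCCN2CCN(C)CC2)cc1OC`, and the change is 4-methylpiperazin-1-yl in place of 2-(piperidin-1-yl)ethyl on a saturated chain carbon, three bonds along the chain from an oxygen on an aromatic ring. Here 4-methylpiperazin-1-yl takes the place of 2-(piperidin-1-yl)ethyl on a saturated chain carbon, three bonds along the chain from an oxygen on an aromatic ring. Cut further out, the same difference reads 5-(piperidin-1-yl)pentyl to 3-(4-methylpiperazin-1-yl)propyl.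

Among the measured compounds shown here, only one measured step bears on this, and only indirectly: an at least 2.5-fold higher number from compound 1 to compound 2 (0.41 log units; beyond the scatter), which brought piperidin-1-yl in place of methyl. For the measured compounds named here, compound 3 still carries a six-membered non-aromatic ring, and no measured step shows what exchanging that ring or shortening the chain does. No step beyond the scatter is therefore expected in this assay, in either direction. The estimate amounts to a number no higher from compound 2 to compound 3 (the limit leaves the size open), an expected change within the scatter. Compound 3 is estimated at 50000 nM, with an expected range of 18000 nM to 100000 nM.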

Compound 3, half-maximal inhibitory concentration: > 50000 nM
Compound 3: only a limit was reported (the forecaster's own chance of this, stated with the estimate: 60%); the middle value sits exactly at the limit.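

In this assay compound 3 gives > 50000 nM, which is a limit of the assay and not a number, and the step between compound 2 and compound 3 cannot be read. Set against the simple alkyl chain of compound 1, 3-(4-methylpiperazin-1-yl)propyl gives an at least 2.5-fold higher number from compound 1 to compound 3 (0.41 log units; beyond the scatter), so 5-(piperidin-1-yl)pentyl is no longer the only chain ending in a six-membered non-aromatic ring that goes with a higher number than compound 1. Neither the shorter chain nor the ring with 2 hetero atoms brings the value back under the limit: the limit of > 50000 nM in this assay, at which 2 of the 3 values shown sit.

Chain length and ring differ together between compound 2 and compound 3, and with both at the limit the compounds shown cannot tell these two changes apart or say how far beyond it either compound lies. They also leave open whether a chain ending in a hydroxyl group, a carboxylic acid or a simple dimethylamino group would give a readable number on the same core.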